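Removing a ring hydroxy from compound 3

A few compounds are considered here, and "the series" means these few. Any claim that something is new, unique, unknown or untested is made for them only; others in the source may bear on it.

Compound 1 `C/C=C(\C)C(=O)O[C@@H]1[C@@H]2OC[C@]3(C)[C@H](OC(C)=O)C[C@H](OC(C)=O)[C@@](C)([C@@H]23)[C@H]2C[C@H](OC)O[C@H]3C[C@@H](C4=CCOC4=O)C(C)=C3[C@]12C`: > 100000 nM (a limit)
Compound 2 `C/C=C(\C)C(=O)O[C@@H]1[C@@H]2OC[C@]3(C)[C@H](OC(=O)/C(C)=C/C)C[C@H](O)[C@@](C)([C@@H]23)[C@H]2C[C@H](OC)O[C@H]3C[C@@H](C4=CCOC4=O)C(C)=C3[C@]12C`: 50000 nM
Compound 3 `C/C=C(\C)C(=O)O[C@@H]1[C@@H]2OC[C@]3(C)[C@H](OC(C)=O)C[C@H](O)[C@@](C)([C@@H]23)[C@H]2C[C@H](O)O[C@H]3C[C@@H](C4=CCOC4=O)C(C)=C3[C@]12C`: 50000 nM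

These three compounds were tested in a functional assay on SMMC-7721 cells (Homo sapiens) for cytotoxicity, read by MTT assay; on this read-out higher numbers stand for weaker inhibition and lower numbers for stronger inhibition. The reading for compound 1 is only a limit of the assay, > 100000 nM. Compound 3 gives 50000 nM and compound 2 gives 50000 nM, so the two are level at the digits shown, within the scatter.

The next compound to be tested is compound 4 `C/C=C(\C)C(=O)O[C@@H]1[C@@H]2OC[C@]3(C)[C@H](OC(C)=O)C[C@H](O)[C@@](C)([C@@H]23)[C@H]2CCO[C@H]3C[C@@H](C4=CCOC4=O)C(C)=C3[C@]12C`. It carries hydrogen in place of hydroxy on a saturated ring carbon of compound 3, and the counted change is hydrogen in place of hydroxy on a saturated ring carbon. Within the data shown here, no measured pair isolates this change, so the expectation in this assay rests on compound 3 at 50000 nM. A step within the scatter is expected, leaning only slightly towards weaker inhibition, and the reading may also end at the limit of the assay. The expected step is a 1.2-fold higher number from compound 3 to compound 4 (0.08 log units; within the scatter). The estimated value for compound 4 is 60000 nM, with an expected range from 25000 nM to 100000 nM.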

Compound 4, half-maximal inhibitory concentration: > 100000 nM
Compound 4: no number, only a limit; the forecaster's own chance of this, stated with the estimate: 35%; at least 1.6-fold (0.22 log units) between middle value and limit.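

Among these compounds, this pair is the first to isolate a change on this saturated ring carbon, next to the ring oxygen of the seven-membered ring. In this assay, hydrogen in place of hydroxy gives an at least 2.0-fold higher number from compound 3 to compound 4 (0.30 log units; that floor lies within the scatter). Removing the hydroxy therefore brings no stronger inhibition, but the size of the step cannot be read beyond that floor, and compound 4 gives only a limit: the limit of > 100000 nM in this assay, at which 2 of the 4 values shown sit.

Methoxy stands on this carbon in compound 1 and compound 2, but each also differs from compound 3 in a further place, so those comparisons cannot be read. From the compounds shown here alone, it remains open whether an amine or a longer alkoxy chain on this carbon would give a reading inside the range of this assay.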